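A few compounds are considered here, and "the series" means these few. Any claim that something is new, unique, unknown or untested is made for them only; others in the source may bear on it.

Measured compounds:
compound 1 `CCN(CC)C(=O)CN(c1cccc(N(C)C)c1C#N)S(=O)(=O)c1ccc(OC)c(OC)c1` — > 10000 nM in a functional assay on CHO cells for inhibition of Orexin/Hypocretin receptor type 1 (Homo sapiens), read by FLIPR and calcium flux; a higher number here means a weaker inhibitor, a lower number a stronger inhibitor
compound 2 `CCN(C(=O)CN(c1cc(N(C)C)ccc1Cl)S(=O)(=O)c1ccc(OC)c(OC)c1)c1ccn(C)n1` — 12 nM
compound 3 `CCN(CC)C(=O)CN(c1ccc(C)cc1)S(=O)(=O)c1ccccc1F` — > 10000 nM

Compound 1 stands at the floor of what this assay reports; its value > 10000 nM is a limit, not a number. The same holds for two of the three values shown: the limit of > 10000 nM in this assay, at which 2 of the 3 values shown sit. Compound 2 alone gives a number. Compound 4 `CCN(CC)C(=O)CN(c1cc(N(C)C)ccc1C#N)S(=O)(=O)c1ccc(OC)c(OC)c1` differs from compound 1 only by 2-cyano-5-(dimethylamino)phenyl in place of 2-cyano-3-(dimethylamino)phenyl on a sulfonamide nitrogen. The step from compound 1 to compound 4 is expected to go well beyond the scatter toward stronger inhibition, an at least 100-fold lower number from compound 1 to compound 4 (2.00 log units; beyond the scatter). Since compound 2 gives 12 nM with its dimethylamino at the 5-position, compound 4 is estimated at 100 nM, between 15 nM and 1000 nM.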

Compound 4, half-maximal inhibitory concentration: 166 nM
Compound 4: the middle estimate sits 1.7-fold (0.22 log units) below what was measured; the range from low to high includes it.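

In this assay, the placing of the same atoms on the aryl group of the sulfonamide nitrogen decides whether the series reads at all: 2-cyano-5-(dimethylamino)phenyl in place of 2-cyano-3-(dimethylamino)phenyl gives an at least 60-fold lower number from compound 1 to compound 4 (1.77 log units; beyond the scatter). Compound 1 gives > 10000 nM, which is a limit and not a number. The full size of the step therefore stays unread: the limit of > 10000 nM in this assay, at which 2 of the 4 values shown sit.

Open, from the compounds shown here alone, is whether a pyrrolidine or a methoxy group in place of the dimethylamino group of compound 4 would hold its value. Also open, going by these compounds, is what a chlorine in place of the nitrile of compound 4 would do alone.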